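Replacing the methylamide of compound 2 with a phenylpyrrolidine amide

The source may report more compounds than this note shows. Statements on the series, on what has been measured and on what is new or still open speak of the compounds shown alone.

Measured compounds:
compound 1 `CNC(=O)[C@@H]1C[C@H](N2CCc3ccccc3C2)CN1C(=O)c1ccc(CN)c(OC)c1`: 490 nM
compound 2 `CNC(=O)[C@@H]1C[C@H](n2cc(C3CC3)nn2)CN1C(=O)c1ccc(CN)c(OC)c1`: 2100 nM

In an assay on isolated protein for inhibition of serine protease 1 (Homo sapiens), read by fluorescence (on this read-out higher numbers stand for weaker inhibition and lower numbers for stronger inhibition), compound 2 gives 2100 nM, the higher of the two numbers recorded so far; compound 1 gives 490 nM, and the one step shown, a 4.3-fold higher number from compound 1 to compound 2 (0.63 log units; beyond the scatter), lies beyond the scatter. That step concerns the group on the saturated ring carbon and leaves the amide untouched.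

Compound 3 `COc1cc(C(=O)N2C[C@@H](n3cc(C4CC4)nn3)C[C@H]2C(=O)N2CC[C@H](c3ccccc3)C2)ccc1CN` changes a different place: 3-phenylpyrrolidin-1-yl in place of methylamino on a carbonyl carbon. Among the compounds with values here, no measured step bears on the carbonyl carbon, so nothing recorded here says how large an effect this change has, or in which direction. The expectation for compound 3 therefore rests on compound 2 alone and carries a wide range: the number for compound 3 is estimated at 1500 nM, between 300 nM and 8000 nM, a step of a 1.4-fold lower number from compound 2 to compound 3 (0.15 log units; within the scatter) that is not expected to exceed the scatter in any reliable way.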

Compound 3, half-maximal inhibitory concentration: 220 nM
Compound 3: the middle estimate sits 6.8-fold (0.83 log units) above what was measured; measured number below the stated range.
By their numbers in this assay, from the lowest: compound 3; then compound 1; then compound 2.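

In this assay, the carbonyl carbon turns out to be a place where the number responds: 3-phenylpyrrolidin-1-yl in place of methylamino gives a 9.5-fold lower number from compound 2 to compound 3 (0.98 log units; beyond the scatter). Within the data shown here, the earlier compounds showed a change only on the saturated ring carbon, so this is the first sign that the amide side matters too, and in the direction of stronger inhibition. The hydrogen-bond donor counted on methylamino is absent from the entering group, so compound 3 reaches its lower number without it, though no evidence available here accounts for the step.

The compounds shown do not separate the contribution of the phenyl ring from that of the pyrrolidine ring, which a plain pyrrolidin-1-yl amide or a dimethylamino amide could address, and the opposite stereocentre on the 3-phenylpyrrolidin-1-yl group remains open. Also open, from the compounds shown here alone, is whether the same amide change would lower the number when 1,2,3,4-tetrahydroisoquinolin-2-yl sits on the saturated ring carbon.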